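Cytotoxicity notes on compounds 1 to 4 in TZM cells

This account rests on a few compounds, and the source may have more. Where it says the series, first, only, none or still open, it means among the compounds named here.

Compound 1 `COc1cc(OC)nc(N2C(=O)CSC2c2ccc(C#N)cc2)n1` has been measured in an ADME assay on TZM cells (Homo sapiens) for cytotoxicity, read by MTT assay, with a stated time of 48 h (on this read-out higher numbers stand for lower toxicity in this test and lower numbers for higher toxicity in this test), and gives 86500 nM. Two further compounds share the core of compound 1 and have been read in the same test: compound 2 `Cc1cc(N2C(=O)CSC2c2c(F)cccc2F)nc(C)c1Br` gives 67100 nM, and compound 3 `O=C1CSC(c2c(F)cccc2F)N1c1ccccn1` gives 90100 nM. All three numbers lie within the usual scatter of one another, so compound 1 cannot be told apart from compound 3 or from compound 2 on these data; nothing here separates the three.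

Compound 4 `COc1cc(OC)nc(N2C(=O)CSC2c2c(Cl)cccc2Cl)n1` is the next compound to be measured. It differs from compound 1 in one place: 2,6-dichlorophenyl in place of 4-cyanophenyl on a saturated ring carbon. Going by the values given here, no pair of measured compounds differing in only one place is available, so the size of this step cannot be read from a precedent. What the three measured compounds do show is that rather different substitution on the shared core leaves the read-out within the scatter, and the same is expected here.

The step from compound 1 to compound 4 is therefore expected to be a 1.1-fold lower number from compound 1 to compound 4 (0.03 log units; within the scatter), that is, none beyond the scatter. Compound 4 is estimated at 80000 nM, within a range of 40000 nM to 160000 nM.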

Compound 4, half-maximal cytotoxic concentration: 85400 nM
Compound 4: the middle estimate sits 1.1-fold (0.03 log units) below what was measured; low and high end bracket the measured number.
By their numbers in this assay, from the lowest: compounds 2, 4, 1 and 3 (each within the scatter of the next).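

Going by these compounds alone, the exchange of 4-cyanophenyl for 2,6-dichlorophenyl on a saturated ring carbon is the first change in one place, and in this assay it appears as a 1.0-fold lower number from compound 1 to compound 4 (0.01 log units; within the scatter), a step that stays inside the usual scatter. The earlier compounds shown here differed in more than one place, so their similar numbers could not be tied to any single position; this pair shows directly that, on the core of compound 1, the two aryl groups at this carbon cannot be told apart on this read-out, even though the triple bond and the hydrogen-bond acceptor of the 4-cyanophenyl group leave and two chlorine atoms enter. No measurement at hand bears on why the two groups read alike.

This single pair leaves open whether a group of another kind on this carbon, such as an amine, a carboxylic acid or a longer alkyl chain, would also stay within the scatter. It also leaves open whether the same exchange would read alike with a different group on the ring nitrogen.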